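The source may report more compounds than this note shows. Statements on the series, on what has been measured and on what is new or still open speak of the compounds shown alone.

Compound 1, `O=C(CN1CCC(c2cccc[n+]2[O-])CC1)NC1CCCCC1`: 58%
Compound 2, `CCc1cccc(NC(=O)CN2CCC(c3cccc[n+]3[O-])CC2)c1`: 62%
Compound 3, `Cc1ccc(Cl)cc1NC(=O)CN1CCC(c2cccc[n+]2[O-])CC1`: 58%

All three compounds share one core and differ only in the group carried on the amide-type nitrogen. In a functional assay on HEK293 cells for agonist activity at D(4) dopamine receptor (Homo sapiens), read by FLIPR (a higher number here means a larger maximal response, a lower number a smaller maximal response), compound 3 gives 58%, which is level with compound 1 at the digits printed and sits within the scatter of compound 2: the three numbers cannot be told apart.

Compound 4, `O=C(CN1CCC(c2cccc[n+]2[O-])CC1)Nc1cccc(Cl)c1Cl`, is the next member of the series and has not yet been measured. It differs from compound 3 in one place: 2,3-dichlorophenyl in place of 5-chloro-2-methylphenyl on an amide-type nitrogen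

Going by the values given here, three measured steps bear on this change, since each of them also exchanges the group on the amide-type nitrogen. From cyclohexyl to 3-ethylphenyl the step was a number 4 percentage points higher from compound 1 to compound 2 (within the scatter); from cyclohexyl to 5-chloro-2-methylphenyl it was no change at the digits printed from compound 1 to compound 3 (within the scatter); and from 3-ethylphenyl to 5-chloro-2-methylphenyl it was a number 4 percentage points lower from compound 2 to compound 3 (within the scatter). None of these left the scatter, so exchanging one substituted phenyl for another on this nitrogen has so far made no difference that can be seen in this assay. The step to compound 4 is therefore expected to stay within the scatter as well, in no particular direction.

On that basis compound 4 is expected to give about 59% in this assay, with a likely range from 46% to 72%. This estimate means an expected step of a number 1 percentage points higher from compound 3 to compound 4 (within the scatter).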

Compound 4, largest response reached (reported as efficacy), in percent of the reference or control that the assay uses: 66%
Estimate against measurement, compound 4: 7 percentage points below; the range from low to high includes it.
By their numbers in this assay, from the lowest: compounds 1, 3, 2 and 4 (each within the scatter of the next).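

Going by these compounds alone, compound 4 is the first member of the series whose ring on the amide-type nitrogen carries chlorine alone, with no alkyl group, and this change still leaves the response in this assay inside the scatter: the step reads a number 8 percentage points higher from compound 3 to compound 4 (within the scatter) and the exchange for the 3-ethylphenyl group reads a number 4 percentage points higher from compound 2 to compound 4 (within the scatter) as well. Even the widest exchange shown, an aromatic ring bearing two chlorines for the saturated cyclohexyl ring, gives a number 8 percentage points higher from compound 1 to compound 4 (within the scatter) and so does not separate the two compounds, which means that all four groups at this position now give numbers that cannot be told apart. No measurement shown here accounts for the numbers at this position, and nothing can be said about why they stay together.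

All the groups shown on this nitrogen are carbon rings, bare or carrying chlorine or small alkyl groups, so it remains open whether an amine, a carboxylic acid or a longer chain there would move the response beyond the scatter. Whether the unsubstituted phenyl group would fall in line with the others also stays unanswered.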